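Methyl to Nitro on the Phenyl Ring: Expected Cytotoxicity

This account rests on a few compounds, and the source may have more. Where it says the series, first, only, none or still open, it means among the compounds named here.

Of the compounds shown here, two have been tested in a functional assay on HeLa cells (Homo sapiens) for cytotoxicity, with a stated time of 72 h; on this read-out higher numbers stand for weaker inhibition and lower numbers for stronger inhibition. Compound 1 `O=[N+]([O-])c1ccc(-c2nc3sc(Cc4ccc(Cl)cc4)nn3c2Br)cc1` carries a nitro-bearing phenyl ring and a bromine on the shared core; in this assay compound 1 gives only the limit > 250000 nM, which is not a number. Compound 2 `Cc1ccc(-c2nc3sc(Cc4ccc(Cl)cc4)nn3c2C=O)cc1` carries a methyl-bearing phenyl ring and a carbonyl on the core; in this assay compound 2 gives 21000 nM. Among the compounds with values here, that is the only true number so far, the other result being a limit (the limit of > 250000 nM in this assay, at which 1 of the 2 values shown sits). Compound 3 `O=Cc1c(-c2ccc([N+](=O)[O-])cc2)nc2sc(Cc3ccc(Cl)cc3)nn12` has not been measured; it differs from compound 2 by nitro in place of methyl on an aromatic carbon. Within the data shown here, the two measured compounds differ in two places, so no single step between them is known. Still, compound 1 also carries the nitro group and sits at the limit of > 250000 nM in this assay, at which 1 of the 2 values shown sits. The step from compound 2 to compound 3 is therefore expected to weaken inhibition, a 2.1-fold higher number from compound 2 to compound 3 (0.33 log units; beyond the scatter). Compound 3 is expected to give about 45000 nM, within 15000 nM to 200000 nM.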

Compound 3, half-maximal inhibitory concentration: 17000 nM
For compound 3 the middle estimate is 2.6-fold (0.42 log units) above the measured one, within the range that was stated.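

The result shows that, with the formyl group held on the core, 4-methylphenyl and 4-nitrophenyl cannot be told apart in this assay: a 1.2-fold lower number from compound 2 to compound 3 (0.09 log units; within the scatter). The change on the core, by contrast, matters far more with the nitro group held fixed, since formyl in place of bromo gives an at least 14-fold lower number from compound 1 to compound 3 (1.16 log units; beyond the scatter). That step rests on compound 1, whose result is a limit of the assay and not a true number: the limit of > 250000 nM in this assay, at which 1 of the 3 values shown sits.

From the compounds shown here alone, it remains open whether an amine or a carboxylic acid at this place on the phenyl ring would also stay within the scatter of compound 2. Going by these compounds, it is also open whether the large step from bromo to formyl would recur with 4-methylphenyl in place of 4-nitrophenyl, and where a carboxylic acid on the core would fall.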